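This account rests on a few compounds, and the source may have more. Where it says the series, first, only, none or still open, it means among the compounds named here.

Working notes on the glycolipid series in a functional assay on K562 cells (Homo sapiens) for antiproliferative activity; on this read-out lower numbers stand for stronger inhibition of growth and higher numbers for weaker inhibition of growth.

Compound 1, `CC(CCCCCCCCCCCCCCCCO[C@@H]1O[C@H](CO)[C@@H](O)[C@H](O)[C@@H]1O)C(=O)C1=C(O)N(C)C(C)C1=O`, carries a free hydroxymethyl on the sugar and in this assay compound 1 gives 33300 nM. Compound 2, `CC(=O)OC[C@H]1O[C@@H](OCCCCCCCCCCCCCCC(C)C(=O)C2=C(O)N(C)C(C)C2=O)[C@@H](O)[C@@H](O)[C@@H]1O`, carries an acetyl on that oxygen; in this assay compound 2 gives 33700 nM. The two numbers do not separate beyond the scatter, so compound 2 stands essentially level with compound 1 and neither can be called the stronger.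

Compound 3, `CC(CCCCCCCCCCCCCCO[C@@H]1O[C@H](CO)[C@@H](O)[C@H](O)[C@@H]1O)C(=O)C1=C(O)N(C)C(C)C1=O`, differs from compound 2 in one place: hydrogen in place of acetyl on an oxygen on a saturated carbon. Going by the values given here, no measured pair in the set shows this exact step, but compound 1 already shows the free hydroxymethyl at 33300 nM, and that number is indistinguishable from compound 2. The step is therefore expected to be a 1.0-fold lower number from compound 2 to compound 3 (0.01 log units; within the scatter), in effect none beyond the scatter. For compound 3 the expected value in this assay is 33000 nM, with a range from 15000 nM to 70000 nM.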

Compound 3, concentration for 50% growth inhibition: > 90000 nM
Compound 3: a limit, no number; the forecaster's own chance of this, stated with the estimate: 10%; middle value at least 2.7-fold (0.43 log units) from the limit.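

Acetoxy to hydroxy at this position is not a silent change: in this assay the step is an at least 2.6-fold higher number from compound 2 to compound 3 (0.42 log units; beyond the scatter), with the chain length unchanged. Compound 1 also carries the hydroxymethyl, but its chain is longer than that of compound 3 and it differs from compound 2 in two places, so its value does not isolate this change. The read-out for compound 3 is a limit and not a number, so the full size of the step cannot be read: the limit of > 90000 nM in this assay, at which 1 of the 3 values shown sits.

On these data alone, whether acetyl on the longer chain of compound 1 would show any step remains open. Also open, as far as these compounds go, is how a propionyl or benzoyl group on this oxygen, or an amine in place of the hydroxyl, would read in this assay.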